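This account rests on a few compounds, and the source may have more. Where it says the series, first, only, none or still open, it means among the compounds named here.

Measured so far in a functional assay on A549 cells (Homo sapiens), read by MTT assay, with a stated time of 72 h; a higher number here means a weaker inhibitor, a lower number a stronger inhibitor:
- compound 1 `COc1ncnc2c1c(-c1cc3ccccc3o1)cn2[C@@H]1O[C@H](CO)[C@@H](O)[C@H]1O`: 17700 nM
- compound 2 `CNc1ncnc2c1c(-c1cc3ccccc3o1)cn2[C@@H]1O[C@H](CO)[C@@H](O)[C@H]1O`: > 20000 nM
- compound 3 `Cc1ncnc2c1c(-c1ccsc1)cn2[C@@H]1O[C@H](CO)[C@@H](O)[C@H]1O`: > 20000 nM

Compound 3 stands at > 20000 nM, which is a limit of the assay and not a number. Compound 2 also reports only a limit, and the data therefore stop at the limit of > 20000 nM in this assay, at which 2 of the 3 values shown sit.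

Compound 4 `Cc1ncnc2c1c(-c1cc3ccccc3o1)cn2[C@@H]1O[C@H](CO)[C@@H](O)[C@H]1O` has not yet been measured. It differs from compound 3 by one exchange, 1-benzofuran-2-yl in place of thiophen-3-yl on an aromatic carbon.

Among the measured compounds shown here, no measured step makes this exchange. For the measured compounds named here, the only measured step is an at least 1.1-fold higher number from compound 1 to compound 2 (0.05 log units; that floor lies within the scatter), and it changes a different group, putting methylamino in place of methoxy. It does show that both compounds carrying 1-benzofuran-2-yl remain weak. Compound 1, the only one of the three with a true number, gives 17700 nM.

The new group is therefore not expected to bring a large gain in this assay. At most a small move towards a lower number seems likely, and none beyond the scatter is just as possible. The expected change is an at least 1.3-fold lower number from compound 3 to compound 4 (0.12 log units; that floor lies within the scatter). For compound 4 the estimated value is 15000 nM, with an expected range from 5000 nM to 25000 nM.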

Compound 4, half-maximal inhibitory concentration: > 20000 nM
Compound 4: only a limit was reported; the forecaster's own chance of this, stated with the estimate: 50%; at least 1.3-fold (0.12 log units) between middle value and limit.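

Placing 1-benzofuran-2-yl instead of thiophen-3-yl on this aromatic carbon brings no readable gain in this assay: compound 3 and compound 4 both report only a limit of the assay, so neither the step between them nor the step from compound 2 to compound 4 can be read. Among the compounds shown here, the one readable step is an at least 1.1-fold higher number from compound 1 to compound 4 (0.05 log units; that floor lies within the scatter), with methyl in place of methoxy on an aromatic carbon, and it does not show how large the true difference is. Any differences among compound 2, compound 3 and compound 4 stay hidden because the data stop at this limit: the limit of > 20000 nM in this assay, at which 3 of the 4 values shown sit.

On these data alone, how far the true values of compound 2, compound 3 and compound 4 lie past the limit remains unknown. As far as these compounds go, it also remains open whether a phenyl group on this aromatic carbon, or a chlorine atom in place of the methyl of compound 4, would give a true number in this assay.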